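The source may report more compounds than this note shows. Statements on the series, on what has been measured and on what is new or still open speak of the compounds shown alone.

Measured so far in a functional assay on DU-145 cells (Homo sapiens) for cytotoxicity, read by MTT assay, with a stated time of 48 h; on this read-out higher numbers stand for weaker inhibition and lower numbers for stronger inhibition:
Compound 1 `COc1ccc(N/C(CCNC2=CC(=O)c3ccccc3C2=O)=N\S(=O)(=O)c2ccc(C)cc2)cc1` gives 12000 nM.
Compound 2 `Cc1ccc(S(=O)(=O)/N=C(/CCNC2=CC(=O)c3ccccc3C2=O)Nc2ccccc2[N+](=O)[O-])cc1` gives 7590 nM.

Among the measured compounds shown here, on these two numbers compound 2 has the lower value, its only neighbour being compound 1, but the one step that connects them, a 1.6-fold lower number from compound 1 to compound 2 (0.20 log units; within the scatter), is within the scatter, so no order between the two can be read from it. The unmeasured compound 3 `Cc1ccc(S(=O)(=O)/N=C(/CCNC2=CC(=O)c3ccccc3C2=O)Nc2cccc(C)c2)cc1` differs from compound 2 at a single point: 3-methylphenyl in place of 2-nitrophenyl on an amine nitrogen. For the measured compounds named here, the only step that bears on this change is the one from compound 1 to compound 2, which also exchanged the group on that amine nitrogen and stayed within the scatter. With nothing beyond that to go on, the account expects no step beyond the scatter in this assay for compound 3, estimated as a 1.3-fold higher number from compound 2 to compound 3 (0.12 log units; within the scatter), giving an expected value of 10000 nM with a range from 4000 nM to 25000 nM.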

Compound 3, half-maximal inhibitory concentration: 10200 nM
Compound 3: the middle estimate sits 1.0-fold (0.01 log units) below what was measured; measured number inside the range.
By their numbers in this assay, from the lowest: compounds 2, 3 and 1 (each within the scatter of the next).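

In this assay the exchange at this amine nitrogen gives a 1.3-fold higher number from compound 2 to compound 3 (0.13 log units; within the scatter) and, measured against the other group, a 1.2-fold lower number from compound 1 to compound 3 (0.07 log units; within the scatter). The three substituted phenyl groups shown here therefore stand within the scatter of one another, even though 3-methylphenyl has 0 hydrogen-bond acceptors and 2-nitrophenyl has 2. Nothing available accounts for this result.

The compounds shown leave open whether a group other than a substituted phenyl on this nitrogen, such as cyclohexyl or benzyl, would give a step beyond the scatter. They also leave open whether a carboxylic acid on the phenyl ring or a longer chain in the shared core would do so.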